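Sulfonamide aryl swap on a benzoxazole-bearing core

This account rests on a few compounds, and the source may have more. Where it says the series, first, only, none or still open, it means among the compounds named here.

Compound 2 `O=S(=O)(Nc1ccc(-c2nc3ccccc3o2)cc1)c1ccccc1Cl` stands at a limit in an assay on cells for inhibition of HSP60/HSP10 (Homo sapiens), with a stated time of 60 min; on this read-out lower numbers stand for stronger inhibition and higher numbers for weaker inhibition: its value of > 100000 nM is a limit of the assay, not a number. Compound 1 `Cc1ccc(S(=O)(=O)Nc2ccc(-c3nc4ccccc4o3)cc2)cc1`, which differs only in the group on the sulfonyl sulfur, likewise gives the limit > 100000 nM in this assay. Going by the values given here, the one measured step, a step that the two limits leave unreadable from compound 1 to compound 2, therefore cannot be read, and the only evidence is the limit of > 100000 nM in this assay, at which 2 of the 2 values shown sit. Compound 3 `O=S(=O)(Nc1ccc(-c2nc3ccccc3o2)cc1)c1cccc(O)c1` carries 3-hydroxyphenyl in place of 2-chlorophenyl on a sulfonyl sulfur. Among the compounds with values here, no measured step bears on this change, so in this assay no direction can be expected with confidence, and the estimated step of a number no higher from compound 2 to compound 3 (the limit leaves the size open) rests on the two limits alone. Compound 3 is therefore expected to give about 100000 nM in this assay, with a range from 20000 nM to 500000 nM, most likely reported again as a limit rather than a number.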

Compound 3, half-maximal inhibitory concentration: 62000 nM
Compound 3: middle estimate off by 1.6-fold (0.21 log units), on the high side, within the range that was stated.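

Going by these compounds alone, on a sulfonyl sulfur, 3-hydroxyphenyl gives the only value in this assay that is a number and not a limit: compound 3 gives 62000 nM. The change reads as an at least 1.6-fold lower number from compound 2 to compound 3 (0.20 log units; that floor lies within the scatter) and as an at least 1.6-fold lower number from compound 1 to compound 3 (0.20 log units; that floor lies within the scatter), so neither floor shows a difference beyond the scatter. The true size of both steps stays unknown, and the other two compounds give only a limit: the limit of > 100000 nM in this assay, at which 2 of the 3 values shown sit.

The compounds shown leave open whether a number in this series depends on the hydroxyl group itself or on the place it holds in the 3-hydroxyphenyl group. Going by these compounds, whether a 3-aminophenyl or a 3-methoxyphenyl group on a sulfonyl sulfur would also give a number, and how that number would compare with that of compound 3, remains open as well.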